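A few compounds are considered here, and "the series" means these few. Any claim that something is new, unique, unknown or untested is made for them only; others in the source may bear on it.

Measured in a physicochemical assay for solubility, using the shake flask method, measured as kinetic solubility, with a stated time of 2 h, at pH 7.4; a higher number here means a more soluble compound, a lower number a less soluble compound:
Compound 1 `COc1ccc(NC(=O)c2cc(N(C)Cc3ccccc3)ncn2)cc1`: < 5000 nM, a limit of the assay and not a number.
Compound 2 `COc1ccc(NC(=O)c2cc(N(C)Cc3cccc(F)c3)ncn2)cc1`: 5000 nM.

Going by the values given here, compound 2 gives the only true number so far, 5000 nM. Compound 1 stands at the limit of < 5000 nM in this assay, at which 1 of the 2 values shown sits.

Compound 3 `COc1ccc(NC(=O)c2cc(N(C)Cc3ccc(F)cc3)ncn2)cc1` has the same atoms as compound 2, joined differently: 4-fluorophenyl in place of 3-fluorophenyl on a saturated chain carbon bound to a nitrogen on an aromatic ring. In words, 4-fluorophenyl stands in place of 3-fluorophenyl on a saturated chain carbon bound to a nitrogen on an aromatic ring.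

Among the compounds with values here, the one measured step that bears on this change is a number no lower from compound 1 to compound 2 (the limit leaves the size open). It gives a direction but no size, so it offers no ground for expecting a real shift in this assay. The expected no change at the digits printed from compound 2 to compound 3 (within the scatter) stays within the scatter. Compound 3 may also be reported only as a limit. For compound 3 the estimated value is 5000 nM, with an expected range of 2500 nM to 12000 nM.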

Compound 3, solubility: 62000 nM
For compound 3 the middle estimate is 12-fold (1.09 log units) below the measured one; the whole stated range lies below it.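

In this assay, with the same atoms joined differently, 4-fluorophenyl in place of 3-fluorophenyl gives a 12-fold higher number from compound 2 to compound 3 (1.09 log units; beyond the scatter), so the read-out at this position depends on where the fluoro stands on the ring and not only on whether it is present. Fluoro in place of hydrogen, which until now had a direction only, reaches an at least 12-fold higher number from compound 1 to compound 3 (1.09 log units; beyond the scatter). Compound 1 remains a limit of the assay and not a number, so that step has a lower bound and no exact size: the limit of < 5000 nM in this assay, at which 1 of the 3 values shown sits.

The compounds shown leave open whether this gain is particular to fluoro or would also appear with 4-chlorophenyl or 4-methoxyphenyl. Also open, from the compounds shown here alone, is whether it survives a longer chain between the nitrogen and the ring.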